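This account rests on a few compounds, and the source may have more. Where it says the series, first, only, none or still open, it means among the compounds named here.

Notes on the series in a functional assay on HeLa cells (Homo sapiens) for inhibition; on this read-out lower numbers stand for stronger inhibition and higher numbers for weaker inhibition. Compound 3 `CC(C)C1NC(=O)N(C2CCCCC2)C1=O` and compound 1 `CCC(C)C1NC(=O)N(C2CCCCC2)C1=O` share a core and differ by methyl in place of hydrogen on a saturated chain carbon, two bonds along the chain from a saturated ring carbon. In this assay compound 3 gives > 100000 nM, which is a limit of the assay and not a number. In this assay compound 1 gives > 100000 nM, again a limit. The step that the two limits leave unreadable from compound 3 to compound 1 is thus unreadable, both values sitting at the limit of > 100000 nM in this assay, at which 2 of the 3 values shown sit. Compound 2 `CC(C)C(NC(=O)n1nnc2ccccc21)C(=O)NC1CCCC1` stands on another core; the difference between the two cores is not broken down here. In this assay, among the compounds with values here, compound 2 gives 96400 nM, the only number among the three values. Compound 4 `CCC(C)C(NC(=O)n1nnc2ccccc21)C(=O)NC1CCCC1` is not yet measured and differs from compound 2 by methyl in place of hydrogen on a saturated chain carbon, three bonds along the chain from an amide-type nitrogen and a carbonyl carbon. This is the same kind of change as from compound 3 to compound 1, but the place differs: two bonds along the chain from a saturated ring carbon there, three bonds along the chain from an amide-type nitrogen and a carbonyl carbon here. With the earlier step unreadable, the expected step is small, a 1.1-fold lower number from compound 2 to compound 4 (0.03 log units; within the scatter). Compound 4 is estimated at 90000 nM, between 40000 nM and 200000 nM, with a fair chance that only a limit is returned.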

Compound 4, half-maximal inhibitory concentration: 82300 nM
Compound 4: the middle estimate sits 1.1-fold (0.04 log units) above what was measured; the measured number falls inside the stated range.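

In this assay, methyl in place of hydrogen on the core of compound 2 gives a 1.2-fold lower number from compound 2 to compound 4 (0.07 log units; within the scatter), so on this core the two values cannot be told apart. Within the data shown here, the same kind of change on the core of compound 3 cannot be read, as compound 3 and compound 1 each give a limit of the assay and not a number: the limit of > 100000 nM in this assay, at which 2 of the 4 values shown sit. The pairs therefore neither confirm nor refute that the change carries from one core to the other, since only one of the two steps is readable and the place differs, two bonds along the chain from a saturated ring carbon on one core and three bonds along the chain from an amide-type nitrogen and a carbonyl carbon on the other.

The compounds shown leave open how a longer chain, an amine or a carboxylic acid would read in place of isopropyl or sec-butyl on either core. They also leave open whether any such group would give a readable number on the core of compound 3.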